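Dropping the chloro between two ring nitrogens on a purine core

The source may hold more compounds than are shown below. What is called first, only, known or untested is meant among the compounds shown, and "the series" means these compounds.

Measured compounds:
compound 1 `ClCc1cccc(Cn2cnc3nc(Cl)nc(Cl)c32)c1` — 1120 nM
compound 2 `Nc1nc(Cl)c2ncn(Cc3cccc(CCl)c3)c2n1` — 2880 nM
compound 3 `ClCc1ccc(Cn2cnc3ncnc(Cl)c32)cc1` — "not determined" (no result reported)

In a functional assay on ACHN cells (Homo sapiens) for cytotoxicity, read by sulforhodamine B assay, with a stated time of 48 h (a higher number here means a weaker inhibitor of growth, a lower number a stronger inhibitor of growth), compound 1 gives 1120 nM, the lower of the two numbers recorded; compound 2 gives 2880 nM, a gap beyond the usual scatter. For compound 3 the entry reads "not determined" (no result reported).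

Compound 4 `ClCc1cccc(Cn2cnc3ncnc(Cl)c32)c1` differs from compound 1 in one place: hydrogen in place of chloro on an aromatic carbon. Within the data shown here, no step between two measured compounds covers exactly this change. Compound 2 carries a different substituent at the same site and is weaker than compound 1, so for compound 4 a modest rise in this assay is expected, about a 1.8-fold higher number from compound 1 to compound 4 (0.25 log units; within the scatter). Compound 4 is therefore estimated at 2000 nM, in the range 800 nM to 5000 nM.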

Compound 4, concentration for 50% growth inhibition: 1860 nM
Estimate against measurement, compound 4: 1.1-fold (0.03 log units) above, and the stated range covers the measured number.
By their numbers in this assay, from the lowest: compounds 1, 4 and 2 (each within the scatter of the next, the first and the last beyond it).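

In this assay, hydrogen in place of chloro on the aromatic carbon between two ring nitrogen atoms gives a 1.7-fold higher number from compound 1 to compound 4 (0.22 log units; within the scatter). Among these compounds, this chloro is therefore not required for growth inhibition of this size, something the earlier compounds could not show, since the site carried a substituent in each measured compound. No evidence is available to explain this result.

Going by these compounds, what a methyl, a methoxy or a carboxylic acid would do at this site stays open. So does the effect of replacing the remaining chloro on the shared core.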